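The source may hold more compounds than are shown below. What is called first, only, known or untested is meant among the compounds shown, and "the series" means these compounds.

Measured compounds:
compound 1 `COc1cccc(CNC(=O)c2cn(CCN(C)C)c3cc(-c4cn[nH]c4)ccc23)c1` — < 1 nM
compound 2 `COc1cccc(CN(C(=O)c2c[nH]c3nc(-c4cn[nH]c4)ccc23)C2CC2)c1` — 6 nM

In an assay on isolated protein for inhibition of Rho-associated protein kinase 2 (Homo sapiens) (a higher number here means a weaker inhibitor, a lower number a stronger inhibitor), compound 1 is reported only as a limit of the assay, < 1 nM, and not as a number; it sits at the limit of < 1 nM in this assay, at which 1 of the 2 values shown sits. Compound 2 gives 6 nM in this assay. These two compounds differ in several places at once, so their values can only be set side by side, without a single step between them. Compound 3 `COc1cccc(CNC(=O)c2cn(-c3ccccc3)c3cc(-c4cn[nH]c4)ccc23)c1` has not yet been measured. Compared with compound 1 it carries phenyl in place of 2-(dimethylamino)ethyl on an aromatic nitrogen. Within the data shown here, no step between measured compounds that differ in one place is known, so the size of this change cannot be read from earlier pairs. The expected step is an at least 3.0-fold higher number from compound 1 to compound 3 (0.47 log units; beyond the scatter), a modest loss that may or may not exceed the usual scatter. Compound 3 is therefore estimated at 3 nM in this assay, within a range from 0.8 nM to 15 nM.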

Compound 3, half-maximal inhibitory concentration: 5 nM
Beside the measured number, compound 3's estimate is 1.7-fold (0.22 log units) below it; the range from low to high includes it.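

In this assay, among these compounds, the change on the aromatic nitrogen now has a size for the first time: phenyl in place of 2-(dimethylamino)ethyl gives an at least 5.0-fold higher number from compound 1 to compound 3 (0.69 log units; beyond the scatter). Compound 1 is reported only as a limit of the assay and not as a number, so this step has a lower bound but no upper one: the limit of < 1 nM in this assay, at which 1 of the 3 values shown sits. With the chain and its amine nitrogen gone and a six-membered aromatic ring of carbon only in their place, compound 3 still gives 5 nM.

This one step swaps the chain for the ring, so it cannot separate losing the amine from gaining the ring. As far as these compounds go, how a 2-hydroxyethyl chain, a plain methyl or a pyridine ring on this nitrogen would compare also remains open.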